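Ring-substituent removal in a pyrazinecarboxylate ester series

The source may hold more compounds than are shown below. What is called first, only, known or untested is meant among the compounds shown, and "the series" means these compounds.

Measured compounds:
- compound 1, `CCOC(=O)/C=C/c1ccc(OC)cc1OC(=O)c1nc(C)c(C)nc1C`, 39.9%
- compound 2, `CCOC(=O)/C=C/c1cc(OC)ccc1OC(=O)c1nc(C)c(C)nc1C`, 46.2%

Both were tested in a functional assay on EA.hy 926 cells (Homo sapiens) for cytotoxicity, read by MTT assay, with stated times of 24 h and 12 h, tested at 100 uM; on this read-out lower numbers stand for a weaker effect and higher numbers for a stronger effect at the one concentration tested. Compound 1 gives 39.9% and compound 2 gives 46.2%; the two numbers differ by an amount that is within the usual scatter, so no order between compound 1 and compound 2 can be read, and compound 2 simply stands alongside compound 1 as one of two numbers of similar size. Among the compounds with values here, there is no pair among the measured compounds that differs in a single place, so nothing is known yet about how a single change moves this read-out.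

Compound 3, `CCOC(=O)/C=C/c1ccccc1OC(=O)c1nc(C)c(C)nc1C`, is the next compound to go into this assay. Its difference from compound 2 is hydrogen in place of methoxy on an aromatic carbon. Within the data shown here, with no single-change step among the measured compounds to draw on, the expectation is that the step from compound 2 to compound 3 is small, a number 3.2 percentage points lower from compound 2 to compound 3 (within the scatter), with no direction beyond the scatter favoured. Compound 3 is thus estimated at 43%, with a range from 28% to 58%.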

Compound 3, a percentage reported as activity, at one concentration (the size of the read-out at that concentration, not a potency): 40.9%
Estimate against measurement, compound 3: 2.1 percentage points above, and the stated range covers the measured number.
By their numbers in this assay, from the lowest: compounds 1, 3 and 2 (each within the scatter of the next).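

Hydrogen in place of methoxy on the aromatic carbon meta to the 2-(ethoxycarbonyl)ethenyl group and para to a large group gives a number 5.3 percentage points lower from compound 2 to compound 3 (within the scatter) in this assay, and the same exchange at the methoxy of compound 1, which sits at another place on that ring, gives a number 1 percentage points higher from compound 1 to compound 3 (within the scatter). Within the data shown here, these are the first single-change steps, and both show that the read-out at the one concentration tested stays within the scatter whether the ring carries a methoxy at either of these two places or none, so at this level of resolution neither methoxy can be said to contribute to the number. No measurement at hand bears on the reason for this.

Going by these compounds, whether a group of another kind at these places, such as an amine, a hydroxyl, a carboxylic acid or a longer alkoxy chain, would move the read-out beyond the scatter remains open. Also open, on these data alone, is how much of the shared effect rests on the ethyl ester or on the ester link to the trimethyl-substituted core, and whether the effects, similar in size at the one concentration tested, would stay similar at other concentrations.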